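A few compounds are considered here, and "the series" means these few. Any claim that something is new, unique, unknown or untested is made for them only; others in the source may bear on it.

The measured compounds, with their values in a functional assay on HT-1080 cells (Homo sapiens) for antiproliferative activity, read by sulforhodamine B assay, with a stated time of 48 h; on this read-out lower numbers stand for stronger inhibition and higher numbers for weaker inhibition:

compound 1, `CC(C)c1ccccc1OS(=O)(=O)c1cccc(NC(=O)C(C)(C)C)c1` — 11000 nM
compound 2, `CC(C)c1ccccc1OS(=O)(=O)c1ccc(NC(=O)C(C)(C)C)cc1` — 11000 nM
compound 3, `CC(C)(C)C(=O)Nc1ccc(S(=O)(=O)Oc2ccccc2I)cc1` — 2600 nM

Compound 2 stands level with compound 1 at the digits given, and the two together hold the highest numbers of the three. Its nearest neighbour is compound 1, whose number does not differ from it at the digits given, which is within the scatter. Its furthest neighbour is compound 3, reached by the step of a 4.2-fold lower number from compound 2 to compound 3 (0.63 log units; beyond the scatter), where iodo takes the place of isopropyl on an aromatic carbon.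

Compound 4, `CCCNC(=O)Nc1ccc(S(=O)(=O)Oc2ccccc2C(C)C)cc1`, differs from compound 2 in one place: propylamino in place of tert-butyl on a carbonyl carbon. Among the measured compounds shown here, no measured step touches this part of the molecule. For the measured compounds named here, the only step that has been measured, from compound 2 to compound 3, concerns the group on the aromatic carbon of the other ring and says nothing about the carbonyl end. In this assay the account therefore has no basis for expecting a move beyond the scatter; the expected step is no change at the digits printed from compound 2 to compound 4 (within the scatter), in no firm direction. Compound 4 is accordingly estimated at 11000 nM, with a range from 4000 nM to 30000 nM.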

Compound 4, half-maximal inhibitory concentration: 680 nM
Compound 4: middle estimate off by 16-fold (1.21 log units), on the high side; the whole stated range lies above it.
By their numbers in this assay, from the lowest: compound 4; then compound 3; then compounds 1 and 2 (each within the scatter of the next).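

In this assay, the carbonyl end of the molecule proves to be a place where a single change moves the number well beyond the scatter: a 16-fold lower number from compound 2 to compound 4 (1.21 log units; beyond the scatter), with propylamino in place of tert-butyl on a carbonyl carbon. The two groups hold the same number of heavy atoms, but the entering group brings a nitrogen and a hydrogen-bond donor that tert-butyl lacks, so the change is one of atom type and not of heavy-atom count. The earlier compounds had shown a printed change only at the aromatic carbon, a 4.2-fold lower number from compound 2 to compound 3 (0.63 log units; beyond the scatter), and the new step at the carbonyl carbon is the larger of the two at the digits printed. No measurement at hand speaks to the cause of this step.

The compounds shown leave open whether the step belongs to the nitrogen or to the chain behind it, a question that ethylamino, butylamino or dimethylamino on the same carbonyl carbon would address. They also leave open whether propylamino on the carbonyl carbon and iodo on the aromatic carbon would add up when carried by one molecule.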